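Stripping the bromoethenyl carbonyl from compound 1

The source may report more compounds than this note shows. Statements on the series, on what has been measured and on what is new or still open speak of the compounds shown alone.

In a functional assay on HeLa cells (Homo sapiens) for antiproliferative activity, with a stated time of 48 h (on this read-out higher numbers stand for weaker inhibition and lower numbers for stronger inhibition), compound 1 `C=C(Br)C(=O)Nc1ccc(/C=C/C(=O)c2ccccc2)cc1` gives 3900 nM. Compound 2 `C=C(Br)C(=O)Nc1ccc(/C=C/C(=O)c2ccc(I)cc2)cc1` gives 7700 nM, and a 2.0-fold higher number from compound 1 to compound 2 (0.30 log units; within the scatter) leaves the two level. Compound 3 `C=C(Br)C(=O)Nc1ccc(/C=C/C(=O)c2cccc(OC)c2)cc1` gives 700 nM, the lowest of the three numbers, with a 5.6-fold lower number from compound 1 to compound 3 (0.75 log units; beyond the scatter). Compound 1 therefore sits with compound 2 at the high end. Unmeasured compound 4 `Nc1ccc(/C=C/C(=O)c2ccccc2)cc1` differs from compound 1 by hydrogen in place of (1-bromoethenyl)carbonyl on a nitrogen on an aromatic ring. Among the measured compounds shown here, none of the measured steps touches that nitrogen, so they offer only a scale, and the data do not fix the direction. Taking an 11-fold lower number from compound 2 to compound 3 (1.04 log units; beyond the scatter) as that scale, a sizeable rise in this assay is expected, though this remains a judgement. The expected change is a 3.8-fold higher number from compound 1 to compound 4 (0.59 log units; beyond the scatter). For compound 4 the estimate is 15000 nM, with an expected range of 5000 nM to 50000 nM.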

Compound 4, half-maximal inhibitory concentration: 36000 nM
The estimate for compound 4 lay 2.4-fold (0.38 log units) below the measured number, and the stated range covers the measured number.
By their numbers in this assay, from the lowest: compound 3; then compounds 1 and 2 (each within the scatter of the next); then compound 4.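

Among the compounds shown, only this step touches the nitrogen on the aromatic ring: in this assay, hydrogen in place of (1-bromoethenyl)carbonyl gives a 9.2-fold higher number from compound 1 to compound 4 (0.97 log units; beyond the scatter) and leaves a free amino group. Among the compounds shown here, this fixes the direction the earlier compounds left unknown, with the number rising when the whole group leaves. Nothing at hand bears on the cause of this rise. The compounds shown leave open whether the bromine, the double bond or the carbonyl accounts for the step, as all leave together. An acetyl or acryloyl group on that nitrogen would help separate these parts.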